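Chain shortening from compound 2 to compound 3

The source may hold more compounds than are shown below. What is called first, only, known or untested is meant among the compounds shown, and "the series" means these compounds.

In a functional assay on MCF7 cells (Homo sapiens) for antiproliferative activity, read by MTT assay, with a stated time of 72 h (a higher number here means a weaker inhibitor, a lower number a stronger inhibitor), compound 1 `CCCCCCCCCCNC[C@@H]1OC[C@H](N)[C@@H]1O` gives 34200 nM and compound 2 `CCCCCCCCNC[C@@H]1OC[C@H](N)[C@@H]1O` gives 96600 nM. For the measured compounds named here, compound 2 therefore holds the higher of the two numbers, and compound 1 is its only measured neighbour. Compound 3 `CCCCCCCNC[C@@H]1OC[C@H](N)[C@@H]1O` differs from compound 2 by hydrogen in place of methyl on a saturated chain carbon, seven bonds along the chain from an amine nitrogen. Going by the values given here, one measured step bears on this change: a 2.8-fold higher number from compound 1 to compound 2 (0.45 log units; beyond the scatter), a modest step beyond the scatter, with hydrogen in place of ethyl eight bonds along the chain. A single step does not establish a trend, but a smaller step in the same direction, towards a higher number, is expected in this assay. The estimated step is a 1.6-fold higher number from compound 2 to compound 3 (0.19 log units; within the scatter). For compound 3 the estimated value is 150000 nM, with an expected range of 85000 nM to 280000 nM.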

Compound 3, half-maximal inhibitory concentration: > 128000 nM
Compound 3 gave a limit, no number; the forecaster's own chance of this, stated with the estimate: 30%; the middle value lies beyond the limit too.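

Compound 3 gives a limit of the assay and not a number in this assay: the limit of > 128000 nM in this assay, at which 1 of the 3 values shown sits.

From the compounds shown here alone, at this position, seven bonds along the chain from an amine nitrogen, hydrogen in place of methyl gives an at least 1.3-fold higher number from compound 2 to compound 3 (0.12 log units; that floor lies within the scatter), so this floor alone does not separate the two compounds and the true size of the step remains unknown. Taken from the longer chain of compound 1, the change gives an at least 3.7-fold higher number from compound 1 to compound 3 (0.57 log units; beyond the scatter), so the direction of the earlier step holds over the whole shortening, while the last single step stays unresolved.

Going by these compounds, whether a longer chain than that of compound 1 would bring the number lower remains open. Also open is what a hydroxyl group or a phenyl group on the chain would give in this assay, since the compounds shown carry only plain saturated chains.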